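The source may report more compounds than this note shows. Statements on the series, on what has been measured and on what is new or still open speak of the compounds shown alone.

Compound 1 (`O=C(O)CCc1c(-c2cccnc2)ccc2c1CCC(NS(=O)(=O)c1ccc(Cl)cc1)C2`) and compound 2 (`O=C(O)CCc1cc(-c2cccnc2)cc2c1CCC(NS(=O)(=O)c1ccc(Cl)cc1)C2`) carry the same groups, arranged differently on a shared core. In a functional assay (Saphenous vein) for inhibition, with Oryctolagus cuniculus as the target (a lower number here means tighter binding, a higher number weaker binding), compound 1 gives 0.2 nM as its dissociation constant, while compound 2 gives 12.6 nM in the same test. Compound 2 therefore has the higher of the two numbers and is the weaker binder, by a gap well beyond the usual scatter of repeat measurements.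

Compound 3 (`O=C(O)CCc1cc(Cc2cccnc2)cc2c1CCC(NS(=O)(=O)c1ccc(Cl)cc1)C2`) departs from compound 2 in one place: (pyridin-3-yl)methyl in place of pyridin-3-yl on an aromatic carbon with (pyridin-3-yl)methyl in place of pyridin-3-yl on an aromatic carbon. For the measured compounds named here, no measured pair shows this exact change, so the data offer no direct guide to its effect. The ring itself stays the same, so no step beyond the scatter is expected in this assay, and neither direction is clearly favoured. The range is kept wide, since compound 1 at 0.2 nM shows how far this core can move when its groups are rearranged. The expected change, a 1.3-fold lower number from compound 2 to compound 3 (0.10 log units; within the scatter) in size, is only an estimate. For compound 3 the estimated value is 10 nM (expected range 2 nM to 50 nM).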

Compound 3, dissociation constant: 0.2 nM
The estimate for compound 3 lay 50-fold (1.70 log units) above the measured number; the whole stated range lies above it.
By their numbers in this assay, from the lowest: compounds 1 and 3 (each within the scatter of the next); then compound 2.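

At this position, the aromatic carbon meta to a 2-carboxyethyl group, the link between the pyridine ring and the core matters a great deal in this assay: replacing pyridin-3-yl with (pyridin-3-yl)methyl gives a 63-fold lower number from compound 2 to compound 3 (1.80 log units; beyond the scatter) for this single edit. The ring itself is the same on both sides, and the hydrogen-bond donor and acceptor counts do not change, so a small alteration to the connection alone is enough to produce a step well beyond the usual scatter. Nothing available here explains why this change produces such a large step.

As far as these compounds go, it remains open whether a longer chain, such as (pyridin-3-yl)ethyl, would hold this tight binding or lose it, and whether an ether oxygen or a carbonyl as the link would act as the methylene of (pyridin-3-yl)methyl does. Also open, from the compounds shown here alone, is whether the same change would have any comparable effect with the pyridine ring placed as it is in compound 1.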